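This account rests on a few compounds, and the source may have more. Where it says the series, first, only, none or still open, it means among the compounds named here.

Working notes on the amide series in a functional assay on HeLa cells (Homo sapiens) for inhibition, read by MTT assay, with a stated time of 72 h; on this read-out higher numbers stand for weaker inhibition and lower numbers for stronger inhibition. Compound 1 `Cc1noc(C)c1-c1cnc(N)c(Oc2ccc(C(=O)NC3CCCC3)cc2)n1` gives 9970 nM, and compound 2 `Cc1noc(C)c1-c1cnc(N)c(Oc2ccc(C(=O)Nc3ccc(Cl)cc3)cc2)n1` gives 2230 nM. Compound 3 `Cc1noc(C)c1-c1cnc(N)c(Oc2ccc(C(=O)Nc3ccc(Cl)cn3)cc2)n1` gives 19200 nM, which lies within the scatter of compound 1 and clearly above compound 2, on the weak side of this small set.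

The next structure is compound 4 `Cc1noc(C)c1-c1cnc(N)c(Oc2ccc(C(=O)Nc3ncccc3Cl)cc2)n1`, with 3-chloropyridin-2-yl in place of 5-chloropyridin-2-yl on an amide-type nitrogen.

Going by the values given here, three measured steps bear on this only indirectly, as all of them change the whole group on the amide-type nitrogen. The largest is an 8.6-fold higher number from compound 2 to compound 3 (0.93 log units; beyond the scatter), and a 4.5-fold lower number from compound 1 to compound 2 (0.65 log units; beyond the scatter) is smaller. Both show that this group can shift the number beyond the scatter. The third, a 1.9-fold higher number from compound 1 to compound 3 (0.28 log units; within the scatter), does not. Among the compounds with values here, no measured pair exchanges one chloropyridinyl isomer for another, so the size and direction of this step are not directly supported. A step as large as the one from 4-chlorophenyl to 5-chloropyridin-2-yl cannot be ruled out, but none beyond the scatter is expected in this assay.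

The estimate means a 1.6-fold lower number from compound 3 to compound 4 (0.20 log units; within the scatter), a small expected drift only. Compound 4 is expected at 12000 nM. The estimated range for compound 4 runs from 4000 nM to 30000 nM.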

Compound 4, half-maximal inhibitory concentration: 31900 nM
Beside the measured number, compound 4's estimate is 2.7-fold (0.42 log units) below it; measured number above the stated range.
By their numbers in this assay, from the lowest: compound 2; then compounds 1, 3 and 4 (each within the scatter of the next, the first and the last beyond it).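

In this assay, going by these compounds alone, the first exchange of one chloropyridinyl isomer for another gives a 1.7-fold higher number from compound 3 to compound 4 (0.22 log units; within the scatter) and so does not separate 3-chloropyridin-2-yl from 5-chloropyridin-2-yl on the amide-type nitrogen. The 4-chlorophenyl amide stays clearly apart from this second isomer as well, with a 14-fold higher number from compound 2 to compound 4 (1.16 log units; beyond the scatter) alongside an 8.6-fold higher number from compound 2 to compound 3 (0.93 log units; beyond the scatter) for the first, so in these compounds the gap to compound 2 appears with either isomer. Against the cyclopentyl amide the reading is less even, since a 3.2-fold higher number from compound 1 to compound 4 (0.51 log units; beyond the scatter) lies beyond the scatter while a 1.9-fold higher number from compound 1 to compound 3 (0.28 log units; within the scatter) stays within it, a split that rests on two chloropyridinyl values that cannot themselves be told apart.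

These compounds leave open whether the chlorine or the ring nitrogen carries the gap to compound 2, a question that an unsubstituted phenyl or pyridin-2-yl on this nitrogen would address, and whether a 4-methoxyphenyl would behave like 4-chlorophenyl. No available evidence bears on the separation of the chloropyridinyl amides from compound 2 or on the lack of separation between the two isomers.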